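Swapping a Chlorophenyl for Benzimidazole on the Triazole Nitrogen

This account rests on a few compounds, and the source may have more. Where it says the series, first, only, none or still open, it means among the compounds named here.

Compound 1, `CN(CCNCc1cn(-c2cccc(Cl)c2)nn1)CCNc1ccnc2cc(Cl)ccc12`: 17000 nM
Compound 2, `CN(CCNCc1cn(-c2ccccc2Cl)nn1)CCNc1ccnc2cc(Cl)ccc12`: 20000 nM
Compound 3, `CN(CCNCc1cn(C(C)(C)C)nn1)CCNc1ccnc2cc(Cl)ccc12`: 79000 nM

These three compounds share one core and differ only in the group carried on an aromatic nitrogen. In a functional assay on NCI-H460 cells (Homo sapiens) for antiproliferative activity, read by sulforhodamine B assay, with a stated time of 72 h (on this read-out higher numbers stand for weaker inhibition and lower numbers for stronger inhibition), compound 2 gives the second highest of the three numbers; compound 1 sits close, a 1.2-fold higher number from compound 1 to compound 2 (0.07 log units; within the scatter), while compound 3 lies further off, a 4.0-fold higher number from compound 2 to compound 3 (0.60 log units; beyond the scatter). Compound 4, `CN(CCNCc1cn(-c2nc3ccccc3[nH]2)nn1)CCNc1ccnc2cc(Cl)ccc12`, is not yet measured and differs from compound 2 by 1H-benzimidazol-2-yl in place of 2-chlorophenyl on an aromatic nitrogen. The step between the two chlorophenyl compounds was within the scatter and the step to tert-butyl was modest; since the entering group again holds a six-membered aromatic ring of carbon only, a small step at most is expected, no change at the digits printed from compound 2 to compound 4 (within the scatter). Compound 4 is therefore estimated at 20000 nM, with a range from 8000 nM to 50000 nM.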

Compound 4, half-maximal inhibitory concentration: 33000 nM
The estimate for compound 4 lay 1.7-fold (0.22 log units) below the measured number; measured number inside the range.
By their numbers in this assay, from the lowest: compounds 1, 2 and 4 (each within the scatter of the next); then compound 3.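

In this assay, the two-ring 1H-benzimidazol-2-yl, which carries a hydrogen-bond donor and acceptor, stays within the scatter of both chlorophenyl compounds (a 1.7-fold higher number from compound 2 to compound 4 (0.22 log units; within the scatter); a 1.9-fold higher number from compound 1 to compound 4 (0.29 log units; within the scatter)). The step from tert-butyl (a 2.4-fold lower number from compound 3 to compound 4 (0.38 log units; beyond the scatter)) shows that this position also accepts an aromatic group with ring nitrogens and still gives a lower number than tert-butyl. Nothing available explains these steps. Open, from the compounds shown here alone, is whether an amine or a carboxylic acid on the aromatic ring would move the number, and whether a saturated ring such as cyclohexyl would track tert-butyl or the aromatic groups.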